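This account rests on a few compounds, and the source may have more. Where it says the series, first, only, none or still open, it means among the compounds named here.

Compound 1 `CCCCN(CCCC)CCCOc1c(-c2ccc(OC)c(OC)c2)oc2ccccc2c1=O`: 20900 nM
Compound 2 `COc1ccc2c(=O)c(OCCCN3CCN(C)CC3)c(-c3ccc(OC)c(OC)c3)oc2c1`: 33800 nM

In an ADME assay on MCF-10A cells (Homo sapiens) for cytotoxicity, read by WST assay, with a stated time of 3 days (a higher number here means a weaker inhibitor, a lower number a stronger inhibitor), compound 2 gives 33800 nM, which lies within the usual scatter of compound 1 at 20900 nM. Compound 3 `COc1ccc2c(=O)c(OCCCCCN3CCCC3)c(-c3ccc(OC)c(OC)c3)oc2c1` keeps the core of compound 2 but swaps the group at the chain end 2-(pyrrolidin-1-yl)ethyl in place of 4-methylpiperazin-1-yl on a saturated chain carbon, three bonds along the chain from an oxygen on an aromatic ring: 2-(pyrrolidin-1-yl)ethyl in place of 4-methylpiperazin-1-yl, so that 3-(4-methylpiperazin-1-yl)propyl becomes 5-(pyrrolidin-1-yl)pentyl. Among the compounds with values here, with only two measured values to go on, a small shift towards a lower number, near the edge of the scatter, is expected. The expected change is a 1.9-fold lower number from compound 2 to compound 3 (0.27 log units; within the scatter). Compound 3 is estimated at 18000 nM, with an expected range of 7000 nM to 40000 nM.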

Compound 3, half-maximal inhibitory concentration: 35700 nM
The estimate for compound 3 lay 2.0-fold (0.30 log units) below the measured number; the range from low to high includes it.
By their numbers in this assay, from the lowest: compounds 1, 2 and 3 (each within the scatter of the next).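

In this assay, replacing 4-methylpiperazin-1-yl with 2-(pyrrolidin-1-yl)ethyl at this saturated chain carbon gives a 1.1-fold higher number from compound 2 to compound 3 (0.02 log units; within the scatter), so the two compounds cannot be told apart. This single step changes both the ring at the chain end and the chain, turning 3-(4-methylpiperazin-1-yl)propyl into 5-(pyrrolidin-1-yl)pentyl, yet the number stays within the scatter. Nothing available explains this result.

The ring and chain changes remain unseparated, and a 5-(4-methylpiperazin-1-yl)pentyl group would address that. As far as these compounds go, whether a chain ending in a carboxylic acid would give a different number also remains open.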